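Ethoxy for Methoxy on a Shared Core at the Limit

A few compounds are considered here, and "the series" means these few. Any claim that something is new, unique, unknown or untested is made for them only; others in the source may bear on it.

Compound 2 `COc1ccccc1Nc1nc(SCc2ccc(C(F)(F)F)cc2)nc2ccccc12` stands at a limit: in a functional assay on HGC-27 cells (Homo sapiens) for cytotoxicity, read by MTT assay, with a stated time of 72 h (a higher number here means a weaker inhibitor, a lower number a stronger inhibitor), compound 2 gives > 50000 nM, which is a limit of the assay and not a number. Its neighbour compound 1 `FC(F)(F)c1ccc(CSc2nc(Nc3ccccc3Cl)c3ccccc3n2)cc1` also stands at a limit. In this assay compound 1 gives > 50000 nM, again a limit rather than a measured number. Going by the values given here, the one step between them, a step that the two limits leave unreadable from compound 1 to compound 2, cannot be read, since both ends sit at the same limit, as the limit of > 50000 nM in this assay, at which 2 of the 2 values shown sit, shows. Compound 3 `CCOc1ccccc1Nc1nc(SCc2ccc(C(F)(F)F)cc2)nc2ccccc12` differs from compound 2 by methyl in place of hydrogen on a saturated chain carbon bound to an oxygen on an aromatic ring. Among the compounds with values here, no measured step shows what adding a methyl at that place does, and the step from chloro to methoxy gave no readable size. Both values shown sit at the limit, and from them no move back into the measurable range is expected. Compound 3 is expected to give in this assay about 70000 nM, within 20000 nM to 250000 nM, most likely again reported only as a limit. The step that the limit leaves unreadable from compound 2 to compound 3 is estimated to be small and within the scatter.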

Compound 3, half-maximal inhibitory concentration: > 50000 nM
Compound 3 was reported as a limit (the forecaster's own chance of this, stated with the estimate: 80%); the middle value does not contradict the limit.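

Compound 3 gives > 50000 nM in this assay, a limit of the assay and not a number. No step among compound 1, compound 2 and compound 3 can be read, since all three sit at the same limit: the limit of > 50000 nM in this assay, at which 3 of the 3 values shown sit.

The compounds shown leave open what methoxy to ethoxy does to potency, and which change to the shared core would give a measurable value.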